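This account rests on a few compounds, and the source may have more. Where it says the series, first, only, none or still open, it means among the compounds named here.

Measured so far in the series:

- compound 1, `CC(=O)Nc1ccc(S(=O)(=O)NNc2ccc(F)cc2)cc1`: 79 nM
- compound 2, `CC(=O)Nc1ccc(S(=O)(=O)NNc2cccc(Br)c2)cc1`: 255 nM

In an assay for inhibition of Indoleamine 2,3-dioxygenase 1 (Homo sapiens), read by spectrophotometry, with stated times of 1 h and 4 h (a lower number here means a stronger inhibitor, a higher number a weaker inhibitor), compound 2 gives 255 nM, the higher of the two numbers recorded; compound 1 gives 79 nM. Going by the values given here, the one step between them is a 3.2-fold higher number from compound 1 to compound 2 (0.51 log units; beyond the scatter), a swap of the halogenated ring on the hydrazine nitrogen, and it is the only step the data hold.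

Compound 3, `CC(=O)Nc1ccc(S(=O)(=O)NNc2ccc(F)c(Br)c2)cc1`, remains to be measured. It differs from compound 2 by fluoro in place of hydrogen on an aromatic carbon. Among the compounds with values here, compound 3 therefore carries the fluoro of compound 1 together with the bromo of compound 2, so the step bearing on it is a 3.2-fold higher number from compound 1 to compound 2 (0.51 log units; beyond the scatter), and no measured pair shows what the two halogens do when both are present. Because a 3.2-fold higher number from compound 1 to compound 2 (0.51 log units; beyond the scatter) was modest and no larger, the fluoro is expected to bring the number part of the way back toward that of compound 1, without clear reason to expect it to fall further.

For compound 3 the expected value in this assay is 130 nM, in the range 55 nM to 310 nM. The estimated step is a 2.0-fold lower number from compound 2 to compound 3 (0.29 log units; within the scatter).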

Compound 3, half-maximal inhibitory concentration: 128 nM
For compound 3 the middle estimate is 1.0-fold (0.01 log units) above the measured one; low and high end bracket the measured number.
By their numbers in this assay, from the lowest: compounds 1, 3 and 2 (each within the scatter of the next, the first and the last beyond it).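

In this assay the fluoro, para to a large group and ortho to a bromo group, gives a 2.0-fold lower number from compound 2 to compound 3 (0.30 log units; within the scatter) and the bromo, with the fluoro already present, gives a 1.6-fold higher number from compound 1 to compound 3 (0.21 log units; within the scatter); compound 3 therefore cannot be ordered against either compound with a single halogen. The series now shows that both halogens can be carried on the same ring with a number that stays within the scatter of compound 1 and of compound 2, even though a 3.2-fold higher number from compound 1 to compound 2 (0.51 log units; beyond the scatter) separates those two compounds. No independent measurement accounts for these numbers.

The compounds shown leave open whether the pattern holds for other groups at the place taken by the fluoro, such as chloro, methoxy or nitrile, or for an amine or a carboxylic acid there. They also leave open how the acetamide and the sulfonyl hydrazine in the shared core contribute, since all three compounds differ only in the halogens on the ring.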